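The compounds below may be only part of what the source reports. "The series", "measured", "known", "first", "only" and "open" are said of these compounds alone.

Measured in a functional assay on HT-29 cells (Homo sapiens) for antiproliferative activity, read by sulforhodamine B assay, with a stated time of 48 h; a higher number here means a weaker inhibitor, a lower number a stronger inhibitor:
Compound 1 `Cc1cc(C)cc(NS(=O)(=O)c2ccc(N3CCNC3=O)cc2)c1`: 82 nM
Compound 2 `COc1ccc(NS(=O)(=O)c2ccc(N3CCNC3=O)cc2)cc1OC`: 520 nM

Of these two, compound 2 has the higher number and is the weaker inhibitor, a gap beyond the scatter. Compound 3 `COc1ccc(NS(=O)(=O)c2ccc(N3CCNC3=O)cc2)cc1`, not yet measured, carries hydrogen in place of methoxy on an aromatic carbon of compound 2, ortho to a methoxy group and meta to a large group (hydrogen in place of methoxy on an aromatic carbon). Among the compounds with values here, no measured pair shows this change, so no step beyond the scatter is expected in this assay. The expected size is a 1.3-fold lower number from compound 2 to compound 3 (0.11 log units; within the scatter). For compound 3 the estimated value is 400 nM, with an expected range from 130 nM to 1300 nM.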

Compound 3, half-maximal inhibitory concentration: 800 nM
For compound 3 the middle estimate is 2.0-fold (0.30 log units) below the measured one, and the stated range covers the measured number.
By their numbers in this assay, from the lowest: compound 1; then compounds 2 and 3 (each within the scatter of the next).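

In this assay hydrogen in place of methoxy on an aromatic carbon, ortho to a methoxy group and meta to a large group, gives a 1.5-fold higher number from compound 2 to compound 3 (0.19 log units; within the scatter) and so does not separate the two groups at this position. Exchanging the whole group on the sulfonamide nitrogen, 4-methoxyphenyl in place of 3,5-dimethylphenyl, gives a 9.8-fold higher number from compound 1 to compound 3 (0.99 log units; beyond the scatter) and does separate those two compounds. Nothing available explains the size of either step. Still open, as far as these compounds go, is whether an amine or a carboxylic acid on this carbon, or a longer chain in place of the methoxy, would stay within the scatter.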